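Carbamate Variation at the Piperidine Nitrogen of a Shared Core

The source may report more compounds than this note shows. Statements on the series, on what has been measured and on what is new or still open speak of the compounds shown alone.

Measured compounds:
compound 1 `Cc1nc(S(C)(=O)=O)ccc1Oc1ncnc(OC2CCN(C(=O)OC(C)C)CC2)c1F` gives 21 nM
compound 2 `Cc1nc(S(C)(=O)=O)ccc1Oc1ncnc(OC2CCN(C(=O)OC(C)(C)CF)CC2)c1F` gives 19.9 nM
compound 3 `Cc1nc(S(C)(=O)=O)ccc1Oc1ncnc(OC2CCN(C(=O)O[C@@H](C)CF)CC2)c1F` gives 186 nM

These three compounds were tested in a functional assay on isolated protein for inhibition of Glucose-dependent insulinotropic receptor (Homo sapiens), read by HTRF and cAMP accumulation; on this read-out lower numbers stand for an effect already at smaller amounts and higher numbers for an effect only at larger amounts of compound. Compound 3 stands at the highest of the three numbers: the step of an 8.9-fold higher number from compound 1 to compound 3 (0.95 log units; beyond the scatter) and the step of a 9.3-fold higher number from compound 2 to compound 3 (0.97 log units; beyond the scatter) are both beyond the scatter, while the step of a 1.1-fold lower number from compound 1 to compound 2 (0.02 log units; within the scatter) is within it.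

Compound 4 `CCC1(OC(=O)N2CCC(Oc3ncnc(Oc4ccc(S(C)(=O)=O)nc4C)c3F)CC2)CC1` has not yet been measured. It differs from compound 3 as follows: 1-ethylcyclopropyl in place of 1-(fluoromethyl)ethyl on an oxygen next to a carbonyl group. This change takes away the fluorine whose entry in the step of an 8.9-fold higher number from compound 1 to compound 3 (0.95 log units; beyond the scatter) raised the number, and it also reverses the loss of the group on the oxygen next to a carbonyl group that in the step of a 9.3-fold higher number from compound 2 to compound 3 (0.97 log units; beyond the scatter) raised the number by about the same amount. Among the compounds with values here, no measured compound carries 1-ethylcyclopropyl itself, so the size of its own effect is not known. Given that compound 1 gives 21 nM and compound 2 gives 19.9 nM, compound 4 is expected to return to that region, so the step of a 7.4-fold lower number from compound 3 to compound 4 (0.87 log units; beyond the scatter) is the estimate. Compound 4 is therefore estimated at 25 nM, with a range from 9 nM to 80 nM.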

Compound 4, half-maximal effective concentration: 22 nM
For compound 4 the middle estimate is 1.1-fold (0.06 log units) above the measured one; measured number inside the range.
By their numbers in this assay, from the lowest: compounds 2, 1 and 4 (each within the scatter of the next); then compound 3.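

In this assay, within the data shown here, 1-ethylcyclopropyl is the first group with a ring on the oxygen next to a carbonyl group, and the change from 1-(fluoromethyl)ethyl gives an 8.5-fold lower number from compound 3 to compound 4 (0.93 log units; beyond the scatter), a step beyond the scatter. Against the two open-chain groups, the readings are a 1.0-fold higher number from compound 1 to compound 4 (0.02 log units; within the scatter) and a 1.1-fold higher number from compound 2 to compound 4 (0.04 log units; within the scatter), both within the scatter, so this position accepts a three-membered ring of carbon only, with no fluorine, without leaving the range of compound 1 and compound 2. Compound 3 now stands apart from all three others, yet fluorine alone does not mark it out, since compound 2 also carries fluorine; no measurement here explains why compound 3 differs.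

On these data alone, it remains open whether the three-membered ring or the ethyl group on it matters for this reading, and whether the opposite stereocentre would change the value of compound 3. The compounds shown also leave open how this position would respond to an amine, a carboxylic acid or a longer chain in place of these small carbon groups.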